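Swapping the distal aryl group: from methyl to methoxy

A few compounds are considered here, and "the series" means these few. Any claim that something is new, unique, unknown or untested is made for them only; others in the source may bear on it.

Measured compounds in a functional assay for agonist activity at G protein-coupled receptor 88 (Homo sapiens), read by HTRF and cAMP accumulation; a lower number here means that less compound is needed, a higher number that more compound is needed for the effect:
compound 1, `CC(C)C[C@H](N)CN(C(=O)[C@@H]1C[C@H]1c1ccccc1)c1ccc(-c2ccsc2)cc1`, compound 1 gives 1200 nM
compound 2, `CC(C)C[C@H](N)CN(C(=O)[C@@H]1C[C@H]1c1ccccc1)c1ccc(C2=CCCCCC2)cc1`, compound 2 gives 2100 nM
compound 3, `Cc1ccc(-c2ccc(N(C[C@@H](N)CC(C)C)C(=O)[C@@H]3C[C@H]3c3ccccc3)cc2)cc1`, compound 3 gives 360 nM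

Compound 3 stands lowest of the three numbers in this assay. The step of a 3.3-fold lower number from compound 1 to compound 3 (0.52 log units; beyond the scatter) and the step of a 5.8-fold lower number from compound 2 to compound 3 (0.77 log units; beyond the scatter) both lie beyond the scatter, whereas a 1.8-fold higher number from compound 1 to compound 2 (0.24 log units; within the scatter) does not; so far, a 4-methylphenyl group at this position gives the lowest number of the three.

Compound 4, `COc1cccc(-c2ccc(N(C[C@@H](N)CC(C)C)C(=O)[C@@H]3C[C@H]3c3ccccc3)cc2)c1`, differs from compound 3 in one place: 3-methoxyphenyl in place of 4-methylphenyl on an aromatic carbon. Within the data shown here, none of the measured steps covers this particular exchange. The two steps that end at compound 3 each replace a different group with 4-methylphenyl, and they say only that an aromatic carbocycle at this position is favourable relative to thiophen-3-yl or cyclohept-1-en-1-yl. Since compound 4 keeps such a ring and changes only the substituent and where it sits, compound 4 is expected to stay close to compound 3, with a 1.4-fold higher number from compound 3 to compound 4 (0.14 log units; within the scatter) expected to fall within or only slightly beyond the scatter. Compound 4 is therefore estimated at 500 nM in this assay, with a range from 180 nM to 1500 nM.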

Compound 4, half-maximal effective concentration: 1100 nM
Compound 4: the middle estimate sits 2.2-fold (0.34 log units) below what was measured; measured number inside the range.
By their numbers in this assay, from the lowest: compound 3; then compounds 4, 1 and 2 (each within the scatter of the next).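

In this assay, a 3.1-fold higher number from compound 3 to compound 4 (0.49 log units; beyond the scatter), so keeping a six-membered aromatic ring of carbon only at this position does not by itself preserve the low number of compound 3; the substituent on that ring, its place on the ring, or both also matter. Compound 4 does not share the separation from the other two groups that compound 3 showed, since a 1.1-fold lower number from compound 1 to compound 4 (0.04 log units; within the scatter) and a 1.9-fold lower number from compound 2 to compound 4 (0.28 log units; within the scatter) both lie within the scatter, and the benefit seen so far therefore belongs to 4-methylphenyl rather than to every substituted phenyl ring at this position. Nothing available bears on the reason for this step.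

The exchange changes the substituent and its place on the ring together, so the compounds shown cannot tell which of the two accounts for the step. They also leave open how this position would respond to an unsubstituted phenyl ring or to a ring carrying a chlorine atom, a nitrile or an amine.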